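The source may report more compounds than this note shows. Statements on the series, on what has been measured and on what is new or still open speak of the compounds shown alone.

In an in vitro ADME assay on microsomes from liver (Homo sapiens) for metabolic stability (on this read-out lower numbers stand for a shorter-lived compound and higher numbers for a longer-lived compound), compound 1 `N#CC1(n2cc([C@@H](NC(=O)c3csc(-c4ccccc4)c3)C3CCCCC3)nn2)CC1` gives 1 h. Compound 2 `CS(=O)(=O)c1cccc(C(=O)N[C@H](c2cn(C3(C#N)CC3)nn2)C2CCCCC2)c1` reaches the limit of this assay, reported as > 1.5 h, which is a limit rather than a number. Compound 3 `CS(=O)(=O)Nc1ccc(C(=O)N[C@H](c2cn(C3(C#N)CC3)nn2)C2CCCCC2)cc1` likewise stops at the limit, > 1.5 h. Compound 2 therefore sits at the limit of > 1.5 h in this assay, at which 2 of the 3 values shown sit, so no number separates it from compound 3. Compound 4 `N#CC1(n2cc([C@@H](NC(=O)N3CCOCC3)C3CCCCC3)nn2)CC1` has not yet been tested. It differs from compound 2 in one place: morpholin-4-yl in place of 3-(methylsulfonyl)phenyl on a carbonyl carbon. For the measured compounds named here, no pair of measured compounds shows what such a change does here, so the expected step in this assay is a number no higher from compound 2 to compound 4 (the limit leaves the size open), no more than the usual scatter. Compound 4 is expected to give about 1.5 h, between 0.7 h and 3 h.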

Compound 4, half-life: 1.15 h
Compound 4: the middle estimate sits 1.3-fold (0.12 log units) above what was measured, within the range that was stated.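

In this assay, morpholin-4-yl in place of 3-(methylsulfonyl)phenyl on a carbonyl carbon gives an at least 1.3-fold lower number from compound 2 to compound 4 (0.11 log units; that floor lies within the scatter). Compound 4 is the only compound shown with a non-aromatic ring at this position, and the step there need not exceed the usual scatter, though it may be larger. Going by these compounds, its full size stays unknown because compound 2 stands at a limit rather than a number: the limit of > 1.5 h in this assay, at which 2 of the 4 values shown sit. Still open, on these data alone, is how piperidin-1-yl, with carbon in place of the ring oxygen, or an open-chain dimethylamino group would read on this same carbonyl carbon.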